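This account rests on a few compounds, and the source may have more. Where it says the series, first, only, none or still open, it means among the compounds named here.

Of the compounds shown here, two have been measured so far in an assay on isolated protein for agonist activity at Bile acid receptor (Homo sapiens), read by TR-FRET; a higher number here means that more compound is needed for the effect, a lower number that less compound is needed. Compound 1 `CC(C)c1onc(-c2c(Cl)cccc2Cl)c1COc1ccc(-c2nc3ccc(C(=O)O)cc3n2CC2CC2)cc1` gives 29.1 nM. Compound 2 `CC(C)Cn1c(-c2ccc(OCc3c(-c4c(Cl)cccc4Cl)noc3C(C)C)cc2)nc2ccc(C(=O)O)cc21` gives 24.7 nM. These two differ only at the group on the aromatic nitrogen of the shared core, and the step there, a 1.2-fold lower number from compound 1 to compound 2 (0.07 log units; within the scatter), is small: the two numbers are within the usual scatter of each other, so neither compound separates from the other on the evidence at hand.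

Compound 3 `CC(C)c1onc(-c2c(Cl)cccc2Cl)c1COc1ccc(-c2nc3ccc(C(=O)O)cc3n2C2CCCCCC2)cc1` carries a different group at that same nitrogen, (cycloheptyl in place of isobutyl on an aromatic nitrogen). Among the compounds with values here, the only measured step that bears on this change is the one between compound 1 and compound 2, where one saturated group on the ring nitrogen was exchanged for another and the result stayed within the scatter. A larger saturated ring is now placed there, which is a bigger alteration than anything measured, so the guide is weak. For compound 3 a number close to that of compound 2 is expected, with wide room to either side, because a 1.2-fold lower number from compound 1 to compound 2 (0.07 log units; within the scatter) gave no sign that this position moves the read-out; the expected step is a 1.3-fold higher number from compound 2 to compound 3 (0.11 log units; within the scatter), giving an estimate for compound 3 of 32 nM, between 12 nM and 90 nM.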

Compound 3, half-maximal effective concentration: 113 nM
Estimate against measurement, compound 3: 3.5-fold (0.55 log units) below; the measured number lies above the stated range.
By their numbers in this assay, from the lowest: compounds 2 and 1 (each within the scatter of the next); then compound 3.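

Unlike the exchange of isobutyl for cyclopropylmethyl, this change at the aromatic nitrogen moves the read-out: cycloheptyl gives a 4.6-fold higher number from compound 2 to compound 3 (0.66 log units; beyond the scatter) and a 3.9-fold higher number from compound 1 to compound 3 (0.59 log units; beyond the scatter) in this assay, and both steps lie beyond the scatter. The position therefore does respond to the group it carries, and the earlier lack of change held only for the pair first compared, with more compound needed once the seven-membered carbon ring replaces either group. Nothing measured here accounts for this rise.

Cycloheptyl differs from isobutyl in two ways at once, as it has more carbon atoms and it is a ring rather than an open chain, so these compounds cannot show which of the two matters. A cyclopentyl or cyclohexyl group would show whether the number climbs gradually with ring size, and a straight heptyl chain, which has the same carbon count as cycloheptyl but no ring, would help separate the effect of the ring from that of the carbon count.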